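A second chloro, expected to change little

The compounds below may be only part of what the source reports. "The series", "measured", "known", "first", "only" and "open" are said of these compounds alone.

Going by the values given here, compound 1 `Cn1c(N2N=C(c3ccccc3)CC2c2ccc(F)cc2)nc(-c2ccccc2)c(C#N)c1=O` is the first of three measured members. In a functional assay on MCF7 cells (Homo sapiens) for antiproliferative activity, with a stated time of 72 h (a higher number here means a weaker inhibitor, a lower number a stronger inhibitor), compound 1 gives 38100 nM. Compound 3 `Cn1c(N2N=C(c3ccccc3)CC2c2ccc(F)cc2)nc(-c2ccc(Cl)cc2)c(C#N)c1=O` carries one further substituent, the difference being (chloro in place of hydrogen on an aromatic carbon). In this assay compound 3 gives 36800 nM, and the step runs a 1.0-fold lower number from compound 1 to compound 3 (0.02 log units; within the scatter). Compound 2 `Cn1c(N2N=C(c3ccccc3)CC2c2ccccc2)nc(-c2ccc(Cl)cc2)c(C#N)c1=O` shares the core but differs from compound 1 in more than one place, so the difference between the two cores is not broken down here. In this assay compound 2 gives 34400 nM. Between compound 2 and compound 3 the single change is a 1.1-fold higher number from compound 2 to compound 3 (0.03 log units; within the scatter), so all three measured numbers lie within the scatter of one another and no order among them can be read.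

Compound 4 `Cn1c(N2N=C(c3ccc(Cl)cc3)CC2c2ccccc2)nc(-c2ccc(Cl)cc2)c(C#N)c1=O` has not yet been measured. It differs from compound 2 by chloro in place of hydrogen on an aromatic carbon. This is the same change as the one from compound 1 to compound 3, and it occurs twice among the compounds shown. Among the compounds with values here, since that earlier step was a 1.0-fold lower number from compound 1 to compound 3 (0.02 log units; within the scatter), the expected step from compound 2 to compound 4 in this assay is a 1.0-fold higher number from compound 2 to compound 4 (0.01 log units; within the scatter), resting on the single measured example of the same change. On that basis compound 4 is estimated at 35000 nM, with the expected range running from 17000 nM to 70000 nM.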

Compound 4, half-maximal inhibitory concentration: 25300 nM
For compound 4 the middle estimate is 1.4-fold (0.14 log units) above the measured one; measured number inside the range.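

In this assay the new step reads a 1.4-fold lower number from compound 2 to compound 4 (0.13 log units; within the scatter), so chloro in place of hydrogen on an aromatic carbon, here phenyl to 4-chlorophenyl, again gives a step that cannot be told apart from the scatter of repeated measurements. Set beside the earlier example, the two steps agree as far as this assay can tell: the same change on two cores in this assay, a 1.0-fold lower number (0.02 log units; within the scatter) from compound 1 to compound 3 and a 1.4-fold lower number (0.13 log units; within the scatter) from compound 2 to compound 4, 1.3-fold (0.12 log units) apart, within the scatter of two such steps This shows that, on these two cores, the change carried over without any step beyond the scatter, but two examples that both lie within it do not show that chloro has any effect on antiproliferative activity in this series, and they say nothing about how it would behave on a further core.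

The compounds shown leave open whether a group of another kind on these aromatic rings, such as an amine, a carboxylic acid or a methoxy group, would give a step beyond the scatter. As far as these compounds go, the nitrile and the methyl group stand unchanged in all four compounds, so what replacing either of them, for instance the methyl with a longer chain, would do to the number also remains open.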